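Replacing Phenylcarbamoyl with Heptyl in Compound 2

The compounds below may be only part of what the source reports. "The series", "measured", "known", "first", "only" and "open" are said of these compounds alone.

In a functional assay on PANC-1 cells (Homo sapiens) for antiproliferative activity, read by sulforhodamine B assay, with a stated time of 48 h (on this read-out higher numbers stand for weaker inhibition of growth and lower numbers for stronger inhibition of growth), compound 1 (`O=c1c2ccc(C(F)(F)F)nc2ncn1Cc1cc(-c2ccc(Br)cc2)no1`) gives 1160 nM and compound 2 (`O=C(Cn1cc(COc2nc(-c3ccccc3)nc3nc(C(F)(F)F)ccc23)nn1)Nc1ccccc1`) gives 4500 nM as the higher of the two numbers, a gap beyond the usual scatter. These two compounds are not a close pair, so they offer no guide to a single structural change. Compound 3 (`CCCCCCCCn1cc(COc2nc(-c3ccccc3)nc3nc(C(F)(F)F)ccc23)nn1`) differs from compound 2 by heptyl in place of phenylcarbamoyl on a saturated chain carbon bound to an aromatic nitrogen and the chain on that nitrogen thus reads as octyl. Within the data shown here, no measured step covers this change, so only a small shift is expected, with no step beyond the scatter. The estimated move in this assay is a 1.5-fold lower number from compound 2 to compound 3 (0.18 log units; within the scatter) and it carries wide uncertainty. For compound 3 the expected value is 3000 nM with an estimated range from 1000 nM to 9000 nM for now.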

Compound 3, concentration for 50% growth inhibition: 2660 nM
Beside the measured number, compound 3's estimate is 1.1-fold (0.05 log units) above it; the measured number falls inside the stated range.
By their numbers in this assay, from the lowest: compound 1; then compounds 3 and 2 (each within the scatter of the next).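

Heptyl in place of phenylcarbamoyl on a saturated chain carbon bound to an aromatic nitrogen gives a 1.7-fold lower number from compound 2 to compound 3 (0.23 log units; within the scatter) in this assay. This exchange takes away the six-membered aromatic ring of carbon only, along with the hydrogen-bond donor and hydrogen-bond acceptor counted in phenylcarbamoyl, yet the read-out does not tell compound 2 and compound 3 apart, so at this position on this core, growth inhibition does not depend on those features. Nothing shown gives a cause for this outcome.

From the compounds shown here alone, it remains open whether an amine, a carboxylic acid or a much shorter chain at this same place would separate from compound 3 by more than the scatter. Going by these compounds, whether the same exchange would read alike on a different core also remains open.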